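The source may hold more compounds than are shown below. What is called first, only, known or untested is meant among the compounds shown, and "the series" means these compounds.

Values in a functional assay on K562 cells (Homo sapiens) for inhibition, read by trypan blue exclusion, with a stated time of 72 h; a lower number here means a stronger inhibitor, a higher number a weaker inhibitor:
- compound 1 `COc1ccc(Nc2ncc3cc(S(=O)(=O)c4ccc(C)cc4)c(=O)n(C)c3n2)cc1`: 75000 nM
- compound 2 `COc1ccc(Nc2ncc3cc(S(=O)(=O)c4ccc(Cl)cc4)c(=O)n(C)c3n2)cc1`: 15000 nM
- compound 3 `Cn1c(=O)c(S(=O)(=O)c2ccc(F)cc2[N+](=O)[O-])cc2cnc(Nc3ccc4[nH]ccc4c3)nc21`: 900 nM

Compound 1 has the highest number of the three. Compound 4 `Cc1ccc(S(=O)(=O)c2cc3cnc(Nc4ccc5ncccc5c4)nc3n(C)c2=O)cc1` has not yet been measured. Its difference from compound 1 is quinolin-6-yl in place of 4-methoxyphenyl on a nitrogen on an aromatic ring.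

Among the compounds with values here, no measured step changes this group alone. Within the data shown here, the only measured step, a 5.0-fold lower number from compound 1 to compound 2 (0.70 log units; beyond the scatter), is chloro in place of methyl on an aromatic carbon, a change at a different place, so it gives only a rough size for a single change. Compound 3, at 900 nM, also carries a different group on that nitrogen, but it differs elsewhere too, so its gap from compound 1 cannot be split between the two changes. Its value does leave room for a lower number.

A modest move towards stronger inhibition is therefore expected, with wide uncertainty: the estimated step is a 6.3-fold lower number from compound 1 to compound 4 (0.80 log units; beyond the scatter). The estimate for compound 4 is 12000 nM, with an expected range of 2500 nM to 50000 nM.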

Compound 4, half-maximal inhibitory concentration: 10000 nM
Estimate against measurement, compound 4: 1.2-fold (0.08 log units) above; measured number inside the range.
By their numbers in this assay, from the lowest: compound 3; then compounds 4 and 2 (each within the scatter of the next); then compound 1.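

In this assay, the change at this position can now be read alone: quinolin-6-yl in place of 4-methoxyphenyl on a nitrogen on an aromatic ring gives a 7.5-fold lower number from compound 1 to compound 4 (0.88 log units; beyond the scatter), with the rest of the structure unchanged. The step shows that this nitrogen substituent can alter the number on its own, even though the swap adds a second ring and leaves the hydrogen-bond acceptor count the same. No data here explain the step.

As far as these compounds go, compound 3, at 900 nM, differs from compound 4 in more than one place, so how much of its value belongs to the group on that nitrogen remains open. Also open, from the compounds shown here alone, are whether the chloro change adds to this step and how an amine or a carboxylic acid on the quinolin-6-yl group would move the number.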